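The compounds below may be only part of what the source reports. "The series", "measured", "known", "first", "only" and "open" are said of these compounds alone.

In a functional assay on KYSE-70 cells for antiproliferative activity against KYSE-70 cell line (Homo sapiens), read by MTT assay, with a stated time of 72 h (on this read-out lower numbers stand for stronger inhibition and higher numbers for weaker inhibition), compound 1 `O=C(Nc1cccc(F)c1)c1cc(=O)[nH]c2cc(-c3cccc(F)c3)ccc12` gives 12000 nM. Compound 2 `O=C(Nc1cccc(F)c1)c1cc(=O)[nH]c2cc(-c3ccncc3)ccc12` gives > 20000 nM, which is a limit and not a number, and so it stands at the limit of > 20000 nM in this assay, at which 1 of the 2 values shown sits. Compound 3 `C#Cc1ccc2c(C(=O)Nc3cccc(F)c3)cc(=O)[nH]c2c1` differs from compound 2 as follows: ethynyl in place of pyridin-4-yl on an aromatic carbon, with ethynyl in place of pyridin-4-yl on an aromatic carbon. For the measured compounds named here, one measured step bears on this change, an at least 1.6-fold higher number from compound 1 to compound 2 (0.22 log units; that floor lies within the scatter), with pyridin-4-yl in place of 3-fluorophenyl, and it gives only a floor for its size. On that thin basis, the expected change is modest and towards lower numbers, an at least 1.6-fold lower number from compound 2 to compound 3 (0.22 log units; that floor lies within the scatter). For compound 3, the estimate is 12000 nM, with an expected range of 3000 nM to 30000 nM.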

Compound 3, half-maximal inhibitory concentration: 9500 nM
Compound 3: middle estimate off by 1.3-fold (0.10 log units), on the high side; the measured number falls inside the stated range.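

In this assay ethynyl in place of pyridin-4-yl on this aromatic carbon gives a step beyond the scatter, an at least 2.1-fold lower number from compound 2 to compound 3 (0.32 log units; beyond the scatter) and its size is only a floor. Compound 2 stands at a limit and not a number: the limit of > 20000 nM in this assay, at which 1 of the 3 values shown sits. Ethynyl in place of 3-fluorophenyl stays within the scatter, a 1.3-fold lower number from compound 1 to compound 3 (0.10 log units; within the scatter) so at this position a group with no ring and the 3-fluorophenyl group are not told apart. The compounds shown leave open how an amine, a carboxylic acid or a longer chain on this carbon would read.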